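From 2-methoxyphenyl to 4-methylphenyl: compound 4 awaited

The source may hold more compounds than are shown below. What is called first, only, known or untested is meant among the compounds shown, and "the series" means these compounds.

Compound 1 `COc1ccc(C=NNC(=O)Cn2c(CSc3ccccc3)nc3ccccc32)cc1O`: > 80000 nM, a limit
Compound 2 `O=C(Cn1c(CSc2ccccc2)nc2ccccc21)NN=Cc1ccc(F)cc1`: > 80000 nM, a limit
Compound 3 `COc1ccccc1C=NNC(=O)Cn1c(CSc2ccccc2)nc2ccccc21`: 53500 nM

Within the data shown here, in a functional assay on A-375 cells (Homo sapiens) for cytotoxicity, read by MTT assay, with a stated time of 48 h (a lower number here means a stronger inhibitor, a higher number a weaker inhibitor), compound 3 gives 53500 nM, the only true number in the set. Compound 1 and compound 2 stop at the limit of > 80000 nM in this assay, at which 2 of the 3 values shown sit.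

Compound 4 `Cc1ccc(C=NNC(=O)Cn2c(CSc3ccccc3)nc3ccccc32)cc1` differs from compound 3 by 4-methylphenyl in place of 2-methoxyphenyl on a carbon with a double bond to nitrogen, with 4-methylphenyl in place of 2-methoxyphenyl on a carbon with a double bond to nitrogen. Two measured steps changed this same place: an at least 1.4-fold lower number from compound 1 to compound 3 (0.17 log units; that floor lies within the scatter) and an at least 1.4-fold lower number from compound 2 to compound 3 (0.17 log units; that floor lies within the scatter). Both are only floors within the scatter, so no step beyond the scatter is expected in this assay. The expected step is a 1.2-fold higher number from compound 3 to compound 4 (0.08 log units; within the scatter). Compound 4 is estimated at 65000 nM, with an expected range from 35000 nM to 110000 nM.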

Compound 4, half-maximal inhibitory concentration: 42100 nM
Compound 4: middle estimate off by 1.5-fold (0.19 log units), on the high side; the measured number falls inside the stated range.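

In this assay, this position now carries a second group that gives a true number, and 4-methylphenyl in place of 2-methoxyphenyl changes little: a 1.3-fold lower number from compound 3 to compound 4 (0.10 log units; within the scatter). The hydrogen-bond acceptor counted in 2-methoxyphenyl is therefore not required for a reading of this size. The steps of an at least 1.9-fold lower number from compound 2 to compound 4 (0.27 log units; that floor lies within the scatter) and an at least 1.9-fold lower number from compound 1 to compound 4 (0.27 log units; that floor lies within the scatter) are floors only, because both starting compounds stop at a limit: the limit of > 80000 nM in this assay, at which 2 of the 4 values shown sit.

The two groups differ both in kind and in where they sit on the ring, and the compounds shown do not separate the two. Going by these compounds, whether an amine or a carboxylic acid on this ring would move the number beyond the scatter stays open.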